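Tetrazole in place of the carboxylic acid: compound 4

The source may hold more compounds than are shown below. What is called first, only, known or untested is meant among the compounds shown, and "the series" means these compounds.

Measured so far in an assay on CHO T-rex cells for antagonist activity at transient receptor potential cation channel subfamily M member 8 (Homo sapiens), read by calcium flux, with a stated time of 20 min; on this read-out higher numbers stand for weaker inhibition and lower numbers for stronger inhibition:
compound 1, `C[C@H](c1ccc(F)cc1)N(Cc1cccc(C(=O)O)c1)C(=O)c1ccc(Oc2ccccc2)cc1`, > 6160 nM
compound 2, `C[C@H](c1ccc(F)cc1)N(Cc1cccc(C(=O)O)c1)C(=O)c1cc2ccccc2cn1`, 90 nM
compound 3, `C[C@H](c1ccc(F)cc1)N(Cc1cc(C(=O)O)ccc1F)C(=O)c1cnc2ccccc2c1`, 446 nM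

The value of compound 1 is a limit of this assay, not a number (the limit of > 6160 nM in this assay, at which 1 of the 3 values shown sits). Two numbers remain, and compound 3 gives the higher of them; compound 2 gives the lower, and the gap between them lies beyond the scatter. Within the data shown here, no pair among the measured compounds differs in a single place, so no measured step is available to lean on.

Compound 4, `C[C@H](c1ccc(F)cc1)N(Cc1cccc(-c2nn[nH]n2)c1)C(=O)c1cnc2ccccc2c1`, has not yet been measured in this assay . It differs from compound 3 in one place: 3-(2H-tetrazol-5-yl)phenyl in place of 5-carboxy-2-fluorophenyl on a saturated chain carbon bound to an amide-type nitrogen. The 2-fluoro substituent leaves at the same time as the acid is exchanged for the tetrazole, so two changes arrive together. Among the measured compounds shown here, with no measured step for either change, the expectation is a step near zero or a modest move to a lower number, within or just beyond the scatter; for compound 4 the estimated result is 300 nM, between 100 nM and 1000 nM, which corresponds to the expected step of a 1.5-fold lower number from compound 3 to compound 4 (0.17 log units; within the scatter).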

Compound 4, half-maximal inhibitory concentration: 1610 nM
The estimate for compound 4 lay 5.4-fold (0.73 log units) below the measured number, and the stated range ends below it.
By their numbers in this assay, from the lowest: compound 2; then compound 3; then compound 4. At a limit, above all of these: compound 1.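

In this assay, among these compounds, putting 3-(2H-tetrazol-5-yl)phenyl in place of 5-carboxy-2-fluorophenyl on a saturated chain carbon bound to an amide-type nitrogen gives a 3.6-fold higher number from compound 3 to compound 4 (0.56 log units; beyond the scatter), the first single-place step, and it shows that inhibition responds to this position. The tetrazole-bearing compound 4 still gives a number rather than a limit, so this exchange weakens inhibition without abolishing it in this read-out. The step belongs to the loss of the fluorine and the exchange of the acid taken together, and nothing shown bears on its cause.

Open, on these data alone, is which of the two changes carries the step: the same core with a carboxylic acid on the phenyl ring and no fluorine would separate them. Also open, as far as these compounds go, is how an acyl sulfonamide in place of the tetrazole would read.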